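From 4-bromophenyl to 2-methoxyphenyl on a shared core

The source may report more compounds than this note shows. Statements on the series, on what has been measured and on what is new or still open speak of the compounds shown alone.

In a functional assay on MCF7 cells (Homo sapiens) for cytotoxicity, read by MTT assay, with a stated time of 96 h (a lower number here means a stronger inhibitor, a higher number a weaker inhibitor), compound 1 (`COc1cc(C(=O)c2cn(-c3ccccc3)cc2-c2cccc(Cl)c2)cc(OC)c1OC`) gives 540 nM, compound 2 (`COc1cc(C(=O)c2cn(-c3ccccc3)cc2-c2ccc(Cl)cc2)cc(OC)c1OC`) gives 290 nM and compound 3 (`COc1cc(C(=O)c2cn(-c3ccccc3)cc2-c2ccc(Br)cc2)cc(OC)c1OC`) gives 340 nM. Compound 3 is not separated from either of the others, as the steps show: a 1.2-fold higher number from compound 2 to compound 3 (0.07 log units; within the scatter), and a 1.6-fold lower number from compound 1 to compound 3 (0.20 log units; within the scatter).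

Compound 4 (`COc1ccccc1-c1cn(-c2ccccc2)cc1C(=O)c1cc(OC)c(OC)c(OC)c1`) carries 2-methoxyphenyl in place of 4-bromophenyl on an aromatic carbon. Going by the values given here, three measured steps bear on this change. Bromo in place of chloro gave a 1.2-fold higher number from compound 2 to compound 3 (0.07 log units; within the scatter), 4-chlorophenyl in place of 3-chlorophenyl gave a 1.9-fold lower number from compound 1 to compound 2 (0.27 log units; within the scatter), and 4-bromophenyl in place of 3-chlorophenyl gave a 1.6-fold lower number from compound 1 to compound 3 (0.20 log units; within the scatter). Among the compounds with values here, none of the measured compounds carries 2-methoxyphenyl, so these steps offer only indirect guidance, and the range must stay wide. No step beyond the scatter is expected in this assay. The expected change is slight, a 1.5-fold higher number from compound 3 to compound 4 (0.17 log units; within the scatter), toward a higher number. For compound 4 the estimated value is 500 nM, with an expected range of 150 nM to 1700 nM.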

Compound 4, half-maximal inhibitory concentration: 190 nM
Estimate against measurement, compound 4: 2.6-fold (0.42 log units) above; the measured number falls inside the stated range.
By their numbers in this assay, from the lowest: compounds 4, 2, 3 and 1 (each within the scatter of the next, the first and the last beyond it).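

In this assay, this position on the shared core takes an aryl group without a halogen: 2-methoxyphenyl gives a 1.8-fold lower number from compound 3 to compound 4 (0.25 log units; within the scatter) when it replaces 4-bromophenyl and a 1.5-fold lower number from compound 2 to compound 4 (0.18 log units; within the scatter) when it replaces 4-chlorophenyl, so compound 4 is not separated from either of these. Against 3-chlorophenyl the same group gives a 2.8-fold lower number from compound 1 to compound 4 (0.45 log units; beyond the scatter) and so supplies the first step in this set that lies beyond the scatter, though only a modest one. Nothing at hand gives a reason for this step.

The compounds shown leave open how 3-methoxyphenyl, 4-methoxyphenyl or plain phenyl would compare at this position, and so whether the methoxy group or its place on the ring matters. They also leave open how a group bearing an amine or a carboxylic acid would fare there.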